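Working notes: from compound 2 to compound 4

The compounds below may be only part of what the source reports. "The series", "measured", "known", "first", "only" and "open" are said of these compounds alone.

Measured so far:
- compound 1 `NS(=O)(=O)c1cc(-c2nnc(CN3CCN(Cc4ccccc4)CC3)o2)c(Cl)cc1SCc1ccccc1`: 26000 nM
- compound 2 `[N-]=[N+]=NCc1nnc(-c2cc(S(N)(=O)=O)c(SCc3ccccc3)cc2Cl)o1`: 100000 nM
- compound 3 `NS(=O)(=O)c1cc(-c2nnc(CNC(=O)c3ccccc3)o2)c(Cl)cc1SCc1ccccc1`: 42000 nM

In a functional assay on HCT-116 cells (Homo sapiens) for cytotoxicity, read by MTT assay, with a stated time of 72 h (a lower number here means a stronger inhibitor, a higher number a weaker inhibitor), compound 2 gives the highest of the three numbers. Its nearest neighbour is compound 3, reached by a 2.4-fold lower number from compound 2 to compound 3 (0.38 log units; beyond the scatter). Compound 1, with its benzylpiperazinylmethyl group on the shared core, stands furthest from compound 2, and in this assay compound 1 gives 26000 nM.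

The unmeasured compound 4 `NS(=O)(=O)c1cc(-c2nnc(/C=C/c3ccccc3)o2)c(Cl)cc1SCc1ccccc1` differs from compound 2 as follows: 2-phenylethenyl in place of azidomethyl on an aromatic carbon. As in the step from compound 2 to compound 3, a small nitrogen-rich group on a saturated chain carbon is exchanged for a larger group carrying a six-membered aromatic ring of carbon only, though here the entering group is bound directly to the aromatic carbon with no chain between. For the measured compounds named here, the one directly bearing step, a 2.4-fold lower number from compound 2 to compound 3 (0.38 log units; beyond the scatter), was modest and downward, and compound 1 with its own aromatic-bearing substituent sits lower still. Going by the values given here, a step of similar size, downward, is therefore expected for compound 4 in this assay; no compound in the set goes the other way, but the set is small.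

Estimated value for compound 4: 35000 nM, in the range 12000 nM to 90000 nM, which means an expected step of a 2.9-fold lower number from compound 2 to compound 4 (0.46 log units; beyond the scatter).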

Compound 4, half-maximal inhibitory concentration: 18000 nM
The estimate for compound 4 lay 1.9-fold (0.29 log units) above the measured number; measured number inside the range.
By their numbers in this assay, from the lowest: compounds 4, 1 and 3 (each within the scatter of the next, the first and the last beyond it); then compound 2.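

In this assay, the place on an aromatic carbon of the five-membered aromatic ring with 2 nitrogen and 1 oxygen now carries a group with no saturated chain carbon, and the number still falls (a 5.6-fold lower number from compound 2 to compound 4 (0.74 log units; beyond the scatter)). The entering 2-phenylethenyl is carbon only, yet it also gives a lower number than the benzamidomethyl group of compound 3 (a 2.3-fold lower number from compound 3 to compound 4 (0.37 log units; beyond the scatter)), so within these compounds neither nitrogen in the substituent nor a saturated chain carbon on the ring is needed for a number lower than that of compound 2. Nothing measured here explains why this change lowers the number.

As far as these compounds go, whether the step belongs to the double bond or to the aromatic ring of carbon stays open, and a saturated 2-phenylethyl chain or a phenyl group bound directly at this place would separate the two. Also open, from the compounds shown here alone, is how a smaller entering group such as methyl, or an amine or a carboxylic acid carried on a longer chain, would behave at this place in this assay.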